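This account rests on a few compounds, and the source may have more. Where it says the series, first, only, none or still open, it means among the compounds named here.

Of the compounds shown here, three have been measured in a functional assay on the whole organism for inhibition, with Mus musculus as the target, with stated times of 30 min and 2 h, at a dose of 10 mg/kg by the intraperitoneal route; on this read-out higher numbers stand for more inhibition at the one dose given (going by the name of the read-out) and lower numbers for less inhibition. Compound 1 `O=C(NCc1ccc(CNS(=O)(=O)c2ccccc2)cc1)c1ccc(F)cc1` gives 40% in this assay, and compound 3 `O=C(NCc1ccc(CNS(=O)(=O)c2ccccc2)cc1)c1cccnc1` gives 53%. Between them stands one comparable step: a number 13 percentage points higher from compound 1 to compound 3 (beyond the scatter). Compound 2 `COc1cccc(C(=O)NCc2ccc(CNS(=O)(=O)c3ccc(C)cc3)cc2)c1` gives 28%, which is the lowest of the three numbers, with compound 1 the nearer and compound 3 the further of the other two.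

Compound 4 `COc1ccccc1C(=O)NCc1ccc(CNS(=O)(=O)c2ccc(C)cc2)cc1` has not yet been measured in this assay. It differs from compound 2 in one place: 2-methoxyphenyl in place of 3-methoxyphenyl on a carbonyl carbon. Within the data shown here, the only measured step, that from compound 1 to compound 3, exchanges a different group on the same carbonyl carbon, and no measured pair shows what moving the methoxy within the ring does. Among the measured compounds shown here, no step therefore bears directly on the change from compound 2 to compound 4, and the number for compound 4 is expected to differ from that of compound 2 by no more than the usual scatter, in no particular direction.

For compound 4 in this assay a value of about 30% is estimated. The expected step is a number 2 percentage points higher from compound 2 to compound 4 (within the scatter). The range within which the measurement for compound 4 is expected to fall runs from 14% to 48%.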

Compound 4, a percentage reported as inhibition, in the whole organism at one dose (the size of the read-out at that dose, not a potency): "not active" (no number reported)
Compound 4: no number reported; the estimate stays without a comparison.
By their numbers in this assay, from the lowest: compound 2; then compound 1; then compound 3.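

Among these compounds, compound 4 is reported as "not active" in this assay with no number, so no step from compound 2 to compound 4 can be read. The compounds shown leave open how large a difference the change from 3-methoxyphenyl to 2-methoxyphenyl makes on this read-out. No evidence at hand bears on this result.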